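A Methoxyphenyl Swap at the Chain Carbon

The source may report more compounds than this note shows. Statements on the series, on what has been measured and on what is new or still open speak of the compounds shown alone.

Among the compounds with values here, compound 2 `COc1cc(/C(=C\c2cn(C(C)=O)c3ccc(OCc4ccccc4)cc23)C(=O)O)cc(OC)c1OC` gives 89100 nM in a functional assay on A549 cells (Homo sapiens) for cytotoxicity, read by MTT assay, with a stated time of 72 h (a lower number here means a stronger inhibitor, a higher number a weaker inhibitor), the highest of the two numbers measured so far; compound 1 `COc1cccc(/C(=C\c2cn(C(C)=O)c3ccc(OCc4ccccc4)cc23)C(=O)O)c1` gives 45200 nM, and a 2.0-fold higher number from compound 1 to compound 2 (0.29 log units; within the scatter) lies within the scatter. Compound 3 `COc1ccccc1/C(=C\c1cn(C(C)=O)c2ccc(OCc3ccccc3)cc12)C(=O)O` carries 2-methoxyphenyl in place of 3,4,5-trimethoxyphenyl on a double-bonded chain carbon bound to a carbonyl carbon and a double-bonded chain carbon. Within the data shown here, the only measured step that bears on this change is a 2.0-fold higher number from compound 1 to compound 2 (0.29 log units; within the scatter), where one methoxyphenyl group was exchanged for another without any shift beyond the scatter. A shift beyond the scatter is therefore not expected here, and compound 3 is estimated at 60000 nM, with a range from 20000 nM to 180000 nM. The expected step is a 1.5-fold lower number from compound 2 to compound 3 (0.17 log units; within the scatter).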

Compound 3, half-maximal inhibitory concentration: 57200 nM
Compound 3: middle estimate off by 1.0-fold (0.02 log units), on the high side; the measured number falls inside the stated range.
By their numbers in this assay, from the lowest: compounds 1, 3 and 2 (each within the scatter of the next).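

In this assay, the 2-methoxyphenyl group on the double-bonded chain carbon gives a 1.6-fold lower number from compound 2 to compound 3 (0.19 log units; within the scatter) and, against the 3-methoxyphenyl group, a 1.3-fold higher number from compound 1 to compound 3 (0.10 log units; within the scatter) as well. Within the data shown here, all three aryl groups therefore read alike at this position, whether the ring carries one methoxy group or three, and moving the single methoxy group also leaves the number within the scatter, which the one earlier step could not show. No measurement shown here offers a reason for this. The compounds shown leave open whether an aminophenyl group or a carboxylic acid on the ring at this carbon would move the number beyond the scatter.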